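The compounds below may be only part of what the source reports. "The series", "measured", "known", "first", "only" and "open" are said of these compounds alone.

Compound 1 `C=C1C[C@]23C[C@@]1(O)CC[C@H]2c1ccc(O)c(C)c1[C@@H]3Cn1cc(-c2ccccn2)nn1` carries a pyridin-2-yl group. In a functional assay on HL-60 cells (Homo sapiens) for cytotoxicity, read by MTT assay, with a stated time of 4 days (a higher number here means a weaker inhibitor, a lower number a stronger inhibitor), compound 1 gives only a limit, > 20000 nM. Compound 2 `C=C1C[C@]23C[C@@]1(O)CC[C@H]2c1cc(Br)c(O)c(C)c1[C@@H]3Cn1cc(-c2ccccn2)nn1` differs from it by bromo in place of hydrogen on an aromatic carbon. In this assay compound 2 likewise gives only a limit, > 20000 nM. The step that the two limits leave unreadable from compound 1 to compound 2 therefore cannot be sized. Compound 3 `C=C1C[C@]23C[C@@]1(O)CC[C@H]2c1ccc(O)c(C)c1[C@@H]3Cn1cc(-c2ccc(C)cc2)nn1` differs from compound 1 by 4-methylphenyl in place of pyridin-2-yl on an aromatic carbon. In this assay compound 3 again returns only a limit, > 20000 nM. The step that the two limits leave unreadable from compound 1 to compound 3 is unreadable as well, since all three values sit at the limit of > 20000 nM in this assay, at which 3 of the 3 values shown sit. Compound 4 `C=C1C[C@]23C[C@@]1(O)CC[C@H]2c1cc(Br)c(O)c(C)c1[C@@H]3Cn1cc(-c2ccc(C)cc2)nn1` is not yet measured; it differs from compound 3 by bromo in place of hydrogen on an aromatic carbon, the same change that leads from compound 1 to compound 2, here made on the core of compound 3 rather than that of compound 1. Within the data shown here, no readable step exists to lean on, and every value so far is a limit. Compound 4 is therefore expected to sit at the limit too, with an expected step that the limit leaves unreadable from compound 3 to compound 4. The estimate for compound 4 is 30000 nM, within a range from 15000 nM to 100000 nM.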

Compound 4, half-maximal inhibitory concentration: > 20000 nM
Compound 4: a limit, no number (the forecaster's own chance of this, stated with the estimate: 90%); the middle value does not contradict the limit.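

In this assay compound 4 gives > 20000 nM as a limit and not a number, so its steps from compound 2 and from compound 3 cannot be read. The compounds shown leave open whether bromo or 4-methylphenyl changes cytotoxicity at all, since they share one limit: the limit of > 20000 nM in this assay, at which 4 of the 4 values shown sit.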